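The source may hold more compounds than are shown below. What is called first, only, known or untested is meant among the compounds shown, and "the series" means these compounds.

Compound 1 `Oc1ccc(-c2cc(-c3ccccc3)nc(-c3ccccc3Cl)c2)cc1`: in a functional assay on T47D cells (Homo sapiens) for cytotoxicity, read by CCK-8 assay and cell counting, with a stated time of 2 days (a higher number here means a weaker inhibitor, a lower number a stronger inhibitor), compound 1 gives 5460 nM.
Compound 3 `Oc1cccc(-c2cc(-c3ccccc3)nc(-c3ccc(Cl)cc3)c2)c1`: in this assay compound 3 gives 11300 nM.
Compound 2 `Oc1cccc(-c2cc(-c3cccnc3)nc(-c3ccccc3Cl)c2)c1`: in this assay compound 2 gives "not determined" (no result reported).

Compound 3 stands highest of the two numbers; the nearest, compound 1, lies beyond the scatter with a lower number, and compound 2 contributes no value. Compound 4 `Oc1cccc(-c2cc(-c3ccccc3)nc(-c3ccccc3Cl)c2)c1` differs from compound 3 in that (2-chlorophenyl in place of 4-chlorophenyl on an aromatic carbon). Within the data shown here, compound 4 carries the same chlorophenyl as compound 1, but no measured pair isolates that change, so the step is expected to be modest: a mild move toward a lower number in this assay, estimated as a 1.5-fold lower number from compound 3 to compound 4 (0.18 log units; within the scatter). Compound 4 is therefore expected to give about 7500 nM, with a range from 3000 nM to 19000 nM.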

Compound 4, half-maximal inhibitory concentration: 2920 nM
Estimate against measurement, compound 4: 2.6-fold (0.41 log units) above; measured number below the stated range.
By their numbers in this assay, from the lowest: compounds 4 and 1 (each within the scatter of the next); then compound 3.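

In this assay the position next to the ring nitrogen proves sensitive to where the chlorine sits: 2-chlorophenyl in place of 4-chlorophenyl gives a 3.9-fold lower number from compound 3 to compound 4 (0.59 log units; beyond the scatter) and so separates the two isomers. With 2-chlorophenyl kept, 3-hydroxyphenyl in place of 4-hydroxyphenyl gives only a 1.9-fold lower number from compound 1 to compound 4 (0.27 log units; within the scatter) and so does not separate that pair. Nothing available here explains either result.

The compounds shown leave open whether a methoxy group or an amine in place of the chlorine would keep this level of activity. They also leave open how far the phenyl group can be replaced.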